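Amide substituent change on the shared core of compound 3

This account rests on a few compounds, and the source may have more. Where it says the series, first, only, none or still open, it means among the compounds named here.

Compound 3 `COCc1cccc(CNC(=O)c2nn(-c3ccc(F)cc3)c(OC[C@@H](O)C[C@@H](O)CC(=O)O)c2C(C)C)c1` gives 31 nM in an assay on microsomes from liver for inhibition of 3-hydroxy-3-methylglutaryl-coenzyme A reductase (Rattus norvegicus) (a higher number here means a weaker inhibitor, a lower number a stronger inhibitor), the second highest of the three numbers at hand. Compound 1 `Cc1ccc(CN(C)C(=O)c2nn(-c3ccc(F)cc3)c(OC[C@@H](O)C[C@@H](O)CC(=O)O)c2C(C)C)cc1` gives 37 nM, and compound 2 `Cc1ccccc1CNC(=O)c1nn(-c2ccc(F)cc2)c(OC[C@@H](O)C[C@@H](O)CC(=O)O)c1C(C)C` gives 17 nM. Compound 4 `CC(C)c1c(C(=O)N(C)Cc2cccc(F)c2)nn(-c2ccc(F)cc2)c1OC[C@@H](O)C[C@@H](O)CC(=O)O` has not yet been measured; it differs from compound 3 by (3-fluorobenzyl)(methyl)amino in place of (3-(methoxymethyl)benzyl)amino on a carbonyl carbon, so the amide hydrogen is replaced by a methyl and the aromatic ring carries fluorine instead of methoxymethyl. For the measured compounds named here, two measured steps bear on this. The step of a 1.2-fold lower number from compound 1 to compound 3 (0.08 log units; within the scatter) swaps a tertiary amide for a secondary one along with a ring change, and the step of a 2.2-fold lower number from compound 1 to compound 2 (0.34 log units; beyond the scatter) does the same with a different ring, while a 1.8-fold higher number from compound 2 to compound 3 (0.26 log units; within the scatter) compares only the rings. Going back to a tertiary amide, he therefore expects the number for compound 4 to sit in this assay within the scatter or slightly above compound 3, an estimated step of a 1.3-fold higher number from compound 3 to compound 4 (0.11 log units; within the scatter). The estimate for compound 4 in this assay is 40 nM, with a range from 15 nM to 110 nM.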

Compound 4, half-maximal inhibitory concentration: 14 nM
For compound 4 the middle estimate is 2.9-fold (0.46 log units) above the measured one; measured number below the stated range.
By their numbers in this assay, from the lowest: compounds 4, 2, 3 and 1 (each within the scatter of the next, the first and the last beyond it).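

In this assay, a tertiary amide at this carbonyl carbon proves compatible with a low number: (3-fluorobenzyl)(methyl)amino in place of (3-(methoxymethyl)benzyl)amino gives a 2.2-fold lower number from compound 3 to compound 4 (0.35 log units; beyond the scatter), while the comparison with the secondary amide carrying (2-methylbenzyl)amino gives a 1.2-fold lower number from compound 2 to compound 4 (0.08 log units; within the scatter). With the amide methyl kept, 3-fluorophenyl in place of 4-methylphenyl gives a 2.6-fold lower number from compound 1 to compound 4 (0.42 log units; beyond the scatter), so among these compounds the ring alone can move the number beyond the scatter, without any change in the amide hydrogen. Nothing available explains these steps.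

The compounds shown do not separate the effect of the amide methyl from that of the ring change between compound 3 and compound 4. On these data alone, whether chlorine in place of the fluorine, or ethyl in place of the amide methyl, would give a similar number also remains open.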